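Swapping the Aryl Group on Compound 2's Benzyl Arm

The source may report more compounds than this note shows. Statements on the series, on what has been measured and on what is new or still open speak of the compounds shown alone.

For the measured compounds named here, compound 2 `Nc1nc(O)c2c(n1)n(C1OC(CO)[C@@H](O)[C@H]1O)c(=O)n2Cc1ccc(Cl)cc1` gives 14 uM in a functional assay (B cells) with Mus musculus as the target (on this read-out higher numbers stand for an effect only at larger amounts of compound and lower numbers for an effect already at smaller amounts), the lower of the two numbers known; compound 1 `CCOC(=O)Cn1c(=O)n(C2OC(CO)[C@@H](O)[C@H]2O)c2nc(N)nc(O)c21` gives 48 uM. Going by the values given here, the only measured step, a 3.4-fold lower number from compound 1 to compound 2 (0.54 log units; beyond the scatter), shows that an aromatic ring at this position beats the ester. Compound 3 `N#Cc1cccc(Cn2c(=O)n(C3OC(CO)[C@@H](O)[C@H]3O)c3nc(N)nc(O)c32)c1` keeps that ring but changes its substituent: 3-cyanophenyl in place of 4-chlorophenyl on a saturated chain carbon bound to an aromatic nitrogen. Among the compounds with values here, no measured pair shows such an aryl-to-aryl swap, so the expected change is small, a 1.4-fold higher number from compound 2 to compound 3 (0.15 log units; within the scatter), within or near the scatter. Compound 3 is therefore estimated at 20 uM, with a likely range from 7 uM to 60 uM.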

Compound 3, concentration for half-maximal effect: 3 uM
For compound 3 the middle estimate is 6.7-fold (0.82 log units) above the measured one, and the stated range ends above it.
By their numbers in this assay, from the lowest: compound 3; then compound 2; then compound 1.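

In this assay, the aromatic groups on this chain carbon are not interchangeable: 3-cyanophenyl in place of 4-chlorophenyl gives a 4.7-fold lower number from compound 2 to compound 3 (0.67 log units; beyond the scatter) and shows that a swap between two aryl groups can shift the number beyond the scatter. Against the ester, the same group gives a 16-fold lower number from compound 1 to compound 3 (1.20 log units; beyond the scatter) and leaves compound 3 with the lowest number of the three. No available evidence explains this gain.

Still open, going by these compounds, is whether the gain follows the nitrile or its ring position; 3-chlorophenyl and 4-cyanophenyl would separate these two changes.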